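This account rests on a few compounds, and the source may have more. Where it says the series, first, only, none or still open, it means among the compounds named here.

Measured so far:
Compound 1, `C=C(C)C(=O)c1ccc(OCc2nc(-c3ccccc3)no2)cc1C`: 1970 nM
Compound 2, `C=C(C)C(=O)c1ccc(OCc2nc(-c3ccc(F)cc3)no2)cc1C`: 3500 nM
Compound 3, `C=C(CC)C(=O)c1ccc(OCc2nc(-c3ccccc3)no2)c(Cl)c1Cl`: 3600 nM

These three were tested in an assay on HL-60 cells for inhibition of glutathione S-transferase P (Homo sapiens); on this read-out higher numbers stand for weaker inhibition and lower numbers for stronger inhibition. The difference between the core of compound 1 and the core of compound 3 is not broken down here; their values differ by less than the usual scatter, as do those of compound 2 and compound 3. Compound 2 differs from compound 1 by fluoro in place of hydrogen on an aromatic carbon, and that change made a 1.8-fold higher number from compound 1 to compound 2 (0.25 log units; within the scatter). Compound 4, `C=C(CC)C(=O)c1ccc(OCc2nc(-c3ccc(F)cc3)no2)c(Cl)c1Cl`, differs from compound 3 by fluoro in place of hydrogen on an aromatic carbon, the same change on the core of compound 3. Because the earlier step was a 1.8-fold higher number from compound 1 to compound 2 (0.25 log units; within the scatter), a step of about a 1.5-fold higher number from compound 3 to compound 4 (0.18 log units; within the scatter) is expected on this core too, staying within the scatter. Compound 4 is therefore estimated at 5500 nM, with a likely range from 2500 nM to 12000 nM, in this assay.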

Compound 4, half-maximal inhibitory concentration: 3900 nM
Compound 4: middle estimate off by 1.4-fold (0.15 log units), on the high side, within the range that was stated.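

In this assay, the change from phenyl to 4-fluorophenyl gave a 1.1-fold higher number from compound 3 to compound 4 (0.03 log units; within the scatter) on the core of compound 3. Set beside the earlier step, the change carried from one core to the other with no difference that can be told apart: the same change on two cores in this assay, a 1.8-fold higher number (0.25 log units; within the scatter) from compound 1 to compound 2 and a 1.1-fold higher number (0.03 log units; within the scatter) from compound 3 to compound 4, 1.6-fold (0.21 log units) apart, within the scatter of two such steps. This shows that on these two cores the step stays within the scatter, but it does not show that fluoro has no effect, nor what size the step would have on any further core.

The compounds shown leave open how a chloro, a methoxy or an amine would read at the same place on the ring. They also leave open whether the step would hold on a core with a longer chain.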